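A few compounds are considered here, and "the series" means these few. Any claim that something is new, unique, unknown or untested is made for them only; others in the source may bear on it.

For the measured compounds named here, in a functional assay on the whole organism (strain Hartley) for inhibition, with Cavia porcellus as the target, with stated times of 15 min and 2 min (a lower number here means that less compound is needed, a higher number that more compound is needed for the effect), compound 1 `CCCCC1([C@H](O)/C=C/C2CCC(=O)[C@@H]2CCCCSCC(=O)OCC)CCC1` gives 0.3 mg/kg, the highest of the three numbers known so far. Compound 2 `CCCCC1([C@H](O)/C=C/C2CCC(=O)[C@@H]2C/C=C\CCCC(=O)OCC)CCC1`, also an ethyl ester, gives 0.135 mg/kg, and compound 3 `CCCCC1([C@H](O)/C=C/C2CCC(=O)[C@@H]2C/C=C\CCCC(=O)O)CCC1`, the matching free acid, gives 0.00767 mg/kg. Compound 4 `CCCCC1([C@H](O)/C=C/C2CCC(=O)[C@@H]2CCCCCCCCC(=O)OCC)CCC1` keeps the core of compound 1 and alters only the chain: 4-(ethoxycarbonyl)butyl in place of ((ethoxycarbonyl)methyl)sulfanyl on a saturated chain carbon, four bonds along the chain from a saturated ring carbon. In words, this is 4-(ethoxycarbonyl)butyl in place of ((ethoxycarbonyl)methyl)sulfanyl on a saturated chain carbon, four bonds along the chain from a saturated ring carbon. The sulfur gives way to carbon, while the ethyl ester stays. Going by the values given here, the only measured step, an 18-fold lower number from compound 2 to compound 3 (1.25 log units; beyond the scatter), is large, but it removes the ethyl group that compound 4 retains, so it says little here. Among the compounds with values here, no measured step replaces the sulfur. The nearest guide is compound 2, with its all-carbon chain and 0.135 mg/kg. Only a small shift in this assay is therefore expected, likely within the scatter, toward a lower number: a 1.5-fold lower number from compound 1 to compound 4 (0.18 log units; within the scatter). The estimate for compound 4 is 0.2 mg/kg, with an expected range from 0.07 mg/kg to 0.6 mg/kg.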

Compound 4, dose for half-maximal effect: 4.38 mg/kg
Estimate against measurement, compound 4: 22-fold (1.34 log units) below; measured number outside the range, above it.
By their numbers in this assay, from the lowest: compound 3; then compound 2; then compound 1; then compound 4.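

Replacing ((ethoxycarbonyl)methyl)sulfanyl with 4-(ethoxycarbonyl)butyl gives a 15-fold higher number from compound 1 to compound 4 (1.16 log units; beyond the scatter) in this assay, so the make-up of this chain can move the number strongly even with the ethyl ester kept; the earlier step showed only the effect of removing that ethyl group. The change is also more than a swap of sulfur for carbon: 7 heavy atoms leave and 9 enter, so the loss of sulfur and the added length arrive together in one step. Nothing available explains the rise.

The compounds shown leave open how much of the step belongs to the sulfur and how much to the length, which a 3-(ethoxycarbonyl)propyl group would help separate. They also leave open how a free carboxylic acid in place of the ethyl ester would read on the chain of compound 4.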